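The compounds below may be only part of what the source reports. "The series", "measured", "known", "first", "only" and "open" are said of these compounds alone.

Working notes on the series. Compound 1 `Nc1scc(CN2CCN(c3cc(Cl)cc(Cl)c3)CC2)c1C(=O)c1ccc(Cl)cc1`, compound 2 `Nc1scc(CN2CCN(c3ccc(Cl)cc3F)CC2)c1C(=O)c1ccc(Cl)cc1` and compound 3 `Nc1scc(CN2CCN(c3ccc(Cl)c(C(F)(F)F)c3)CC2)c1C(=O)c1ccc(Cl)cc1` share one core and differ only in the aryl group on an amine nitrogen in a ring. In an assay on CHO cells for displacement of a labelled ligand from adenosine receptor A1 (Homo sapiens), read by scintillation counting, with a stated time of 120 min, tested at 10 uM (on this read-out higher numbers stand for more inhibition at the one concentration tested (going by the name of the read-out) and lower numbers for less inhibition), compound 1 gives 1%, compound 2 gives 0% and compound 3 gives 0%. The three numbers sit at the floor of the read-out: a number 1 percentage points lower from compound 1 to compound 2 (within the scatter), a number 1 percentage points lower from compound 1 to compound 3 (within the scatter) and no change at the digits printed from compound 2 to compound 3 (within the scatter), all within the scatter, so compound 3 stands level with compound 2 and indistinguishable from compound 1.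

Compound 4 `Nc1scc(CN2CCN(c3ccc(Cl)c(Cl)c3)CC2)c1C(=O)c1ccc(Cl)cc1` is the next member. Relative to compound 3 the change is chloro in place of trifluoromethyl on an aromatic carbon. Within the data shown here, the steps that bear on it are the two exchanges of substituents on the same aryl ring, a number 1 percentage points lower from compound 1 to compound 3 (within the scatter) and no change at the digits printed from compound 2 to compound 3 (within the scatter), both flat. Among the measured compounds shown here, nothing among the measured compounds suggests that any substituent pattern on this ring lifts the read-out, so the expected step is a number 1 percentage points higher from compound 3 to compound 4 (within the scatter), that is none beyond the scatter. Compound 4 is therefore estimated at 1%, with a range of -8% to 10%.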

Compound 4, a percentage reported as inhibition, at one concentration (the size of the read-out at that concentration, not a potency): 1%
Estimate against measurement, compound 4: no gap at the digits printed; measured number inside the range.
By their numbers in this assay, from the lowest: compounds 2, 3, 1 and 4 (each within the scatter of the next).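

In this assay, chloro in place of trifluoromethyl on this aromatic carbon, ortho to a chloro group, gives a number 1 percentage points higher from compound 3 to compound 4 (within the scatter), so this exchange leaves the read-out at its floor. The 3,4-dichlorophenyl group also stands level with the other two aryl groups, with a number 1 percentage points higher from compound 2 to compound 4 (within the scatter) and no change at the digits printed from compound 1 to compound 4 (within the scatter), and none of the aryl groups shown separates from the others. No supporting data explain this flat read-out.

On these data alone, whether a hydroxyl, a methoxy or an amine on this aryl ring would lift the number off the floor remains open. Also open, as far as these compounds go, is whether a carboxylic acid or a longer chain at this position would give any measurable displacement with the shared core unchanged.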